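Methylation of a phenol on two related cores

The compounds below may be only part of what the source reports. "The series", "measured", "known", "first", "only" and "open" are said of these compounds alone.

Compound 1 `COc1cc(OC)cc(-c2cc3ccccc3c(-c3cccc(O)c3)n2)c1` carries a hydroxy group on one aryl ring, and in an ADME assay on MCF-10A cells (Homo sapiens) for cytotoxicity, read by CCK-8 assay and cell counting, with a stated time of 72 h (a higher number here means a weaker inhibitor, a lower number a stronger inhibitor), compound 1 gives 6770 nM. Compound 2 `COc1cc(OC)cc(-c2cc3ccccc3c(-c3cccc(OC)c3)n2)c1` differs from compound 1 by methyl in place of hydrogen on an oxygen on an aromatic ring. In this assay compound 2 reaches only > 50000 nM, which is a limit of the assay and not a number. The step of an at least 7.3-fold higher number from compound 1 to compound 2 (0.86 log units; beyond the scatter) is therefore a lower bound on the change, because the limit of > 50000 nM in this assay, at which 1 of the 3 values shown sits, caps what the assay can report.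

Compound 3 `COc1ccc(-c2cc3cc(C)ccc3c(-c3ccc(O)cc3)n2)cc1OC` is built on a different core; the difference between the two cores is not broken down here. In this assay compound 3 gives 18100 nM, the higher of the two numbered values, with compound 1 below it by a step beyond the scatter.

Compound 4 `COc1ccc(-c2nc(-c3ccc(OC)c(OC)c3)cc3cc(C)ccc23)cc1` has not yet been measured. It differs from compound 3 by methyl in place of hydrogen on an oxygen on an aromatic ring, the same change as that from compound 1 to compound 2, at a place that reads the same in both pairs; cut one bond further out, one reads 3-hydroxyphenyl to 3-methoxyphenyl and the other 4-hydroxyphenyl to 4-methoxyphenyl. The only basis for an expectation is the earlier step of an at least 7.3-fold higher number from compound 1 to compound 2 (0.86 log units; beyond the scatter). On that basis the expected step is a 5.0-fold higher number from compound 3 to compound 4 (0.70 log units; beyond the scatter). Compound 4 is expected around 90000 nM, between 30000 nM and 300000 nM, and the assay will most probably report only a limit.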

Compound 4, half-maximal inhibitory concentration: > 50000 nM
Compound 4: a limit, no number (the forecaster's own chance of this, stated with the estimate: 70%); the middle value does not contradict the limit.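

In this assay compound 4 gives > 50000 nM, which is a limit of the assay and not a number. In the two pairs shown, replacing the hydrogen on the phenol oxygen with methyl moves the number in the same direction on both cores, and the second pair gives an at least 2.7-fold higher number from compound 3 to compound 4 (0.44 log units; beyond the scatter), a lower bound on the change. This shows that the direction held in these two pairs, but it gives no size for the change on either core and does not show that the size carries from one core to the other: the same change on two cores in this assay, an at least 7.3-fold higher number (0.86 log units; beyond the scatter) from compound 1 to compound 2 and an at least 2.7-fold higher number (0.44 log units; beyond the scatter) from compound 3 to compound 4; the limit leaves it open whether they differ.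

The compounds shown leave open whether a 3-hydroxyphenyl and a 4-hydroxyphenyl group behave alike on one and the same core, since the two pairs differ in that place as well as in their cores. They also leave open what an amine, a carboxylic acid or a longer chain such as ethoxy would do in place of the hydroxy group, and how far the methoxy compounds really lie from their hydroxy partners remains out of reach: the limit of > 50000 nM in this assay, at which 2 of the 4 values shown sit.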